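Replacing the ring-nitrogen methyl with 4-bromophenyl

The source may report more compounds than this note shows. Statements on the series, on what has been measured and on what is new or still open speak of the compounds shown alone.

Three ureas have been measured in an assay on isolated protein for inhibition of Ephrin type-A receptor 2 (Homo sapiens), read by thermal shift assay, tested at 10 uM; a higher number here means that the compound stabilises the target more against heat, a lower number that the compound stabilises the target less. Compound 1 `CCOc1ccc(NC(=O)Nc2cc(C(C)(C)C)nn2-c2ccccc2)cc1` gives 1 degrees C, compound 2 `Cc1ccc(NC(=O)Nc2cc(C(C)(C)C)nn2-c2ccccc2)cc1` gives 1.7 degrees C, and compound 3 `Cn1nc(C(C)(C)C)cc1NC(=O)Nc1cc(C(F)(F)F)cc(C(F)(F)F)c1` gives 0.4 degrees C. Compound 3 sits within the scatter of compound 1 and beyond it against compound 2. For the measured compounds named here, the only step between measured neighbours, a number 0.70 degrees C higher from compound 1 to compound 2 (within the scatter), concerns a substituent on an aromatic carbon and is small. Compound 4 `CC(C)(C)c1cc(NC(=O)Nc2cc(C(F)(F)F)cc(C(F)(F)F)c2)n(-c2ccc(Br)cc2)n1` differs from compound 3 by 4-bromophenyl in place of methyl on an aromatic nitrogen. Going by the values given here, no measured step touches this ring nitrogen, so the change has no direct precedent here; the expectation is a step of no more than the scatter in this assay, a number 0.60 degrees C higher from compound 3 to compound 4 (within the scatter). Compound 4 is therefore estimated at 1 degrees C, with a range from -0.5 degrees C to 2.5 degrees C.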

Compound 4, shift of the target's melting temperature: 0.3 degrees C
The estimate for compound 4 lay 0.70 degrees C above the measured number, within the range that was stated.
By their numbers in this assay, from the lowest: compounds 4, 3, 1 and 2 (each within the scatter of the next, the first and the last beyond it).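

For the compounds shown here, at the ring nitrogen, which no earlier step had touched, the change gives a number 0.10 degrees C lower from compound 3 to compound 4 (within the scatter) in this assay. Exchanging methyl for 4-bromophenyl thus adds a six-membered aromatic ring and 6 further heavy atoms at this position, yet the two compounds are not separated by this read-out. No evidence is available that bears on this result.
On these data alone, whether an amine or a carboxylic acid in place of the bromine on that ring would move the number remains open. So does the effect of a longer alkyl chain on this ring nitrogen.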